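The source may hold more compounds than are shown below. What is called first, only, known or untested is meant among the compounds shown, and "the series" means these compounds.

Three compounds share one core and differ only in the group that hangs from the benzyl ring. Compound 1 `O=[N+]([O-])c1ccc(CNc2cc(C(F)(F)F)cc3[nH]ncc23)cc1` carries a nitro group and in an assay for inhibition of Indoleamine 2,3-dioxygenase 1 (Homo sapiens), with stated times of 10 min and 60 min, tested at 100 uM (a lower number here means a weaker effect, a higher number a stronger effect of the compound at the concentration tested), compound 1 gives 61%. Compound 2 `O=[N+]([O-])c1cccc(CNc2cc(C(F)(F)F)cc3[nH]ncc23)c1` places the nitro group elsewhere on the ring, and in this assay compound 2 gives 69%. Compound 3 `O=[N+]([O-])c1ccc2[nH]c(CNc3cc(C(F)(F)F)cc4[nH]ncc34)cc2c1` sets the nitro group on a fused two-ring system, and in this assay compound 3 gives 38%. Compound 2 stands highest of the three numbers, yet compound 1 lies within the usual scatter of it, so the two cannot be told apart; compound 3 lies clearly lower.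

Compound 4 `CNC(=O)c1cccc(CNc2cc(C(F)(F)F)cc3[nH]ncc23)c1` is not yet measured. It differs from compound 2 in one place: methylcarbamoyl in place of nitro on an aromatic carbon. Among the measured compounds shown here, no measured pair shows this change, so nothing in the data says how large a step to expect. With the nitro group gone, a modest drop seems the more likely outcome, and the step from compound 2 to compound 4 is expected to be a number 27 percentage points lower from compound 2 to compound 4 (beyond the scatter). Compound 4 is therefore estimated at 42%, with a range from 15% to 65%.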

Compound 4, a percentage reported as inhibition, at one concentration (the size of the read-out at that concentration, not a potency): 46%
The estimate for compound 4 lay 4 percentage points below the measured number; measured number inside the range.
By their numbers in this assay, from the lowest: compounds 3 and 4 (each within the scatter of the next); then compounds 1 and 2 (each within the scatter of the next).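

Swapping nitro for methylcarbamoyl on this aromatic carbon, meta to a large group, gives a number 23 percentage points lower from compound 2 to compound 4 (beyond the scatter) in this assay. This position therefore responds to the group placed on it, yet the nitro group is not required for a measurable effect, as compound 4 still gives 46% without it. Nothing measured here explains the drop, so the entry of a hydrogen-bond donor with the methylcarbamoyl group remains a description of the change and not a cause.

The compounds shown leave open whether a carboxylic acid, an amine or a nitrile on the same carbon would give a number closer to that of compound 2 or compound 4. From the compounds shown here alone, it also remains open whether methylcarbamoyl in the place where compound 1 carries its nitro group would produce a similar step.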